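This account rests on a few compounds, and the source may have more. Where it says the series, first, only, none or still open, it means among the compounds named here.

Measured compounds:
compound 1, `CC(C)(C)OC(=O)N[C@@H](CCC(=O)NCCOc1ccc(C2=[N+]([O-])C(C)(C)C(C)(C)N2O)cc1)C(=O)O`, in a functional assay on PC-12 cells (Rattus norvegicus) for inhibition, read by MTT assay; on this read-out higher numbers stand for an effect only at larger amounts of compound and lower numbers for an effect already at smaller amounts: 42700 nM
compound 2, `CC1(C)N(O)C(c2ccc(OCCNC(=O)CC[C@H](N)C(=O)O)cc2)=[N+]([O-])C1(C)C`, in this assay: 41800 nM

Compound 2 sits beside compound 1 on the numbers shown; the step of a 1.0-fold lower number from compound 1 to compound 2 (0.01 log units; within the scatter) separates them, and the two numbers therefore cannot be told apart. Compound 3, `CC1(C)N(O)C(c2ccc(OCCNC(=O)CC[C@H](N)C(=O)N[C@H](CS)C(=O)NCC(=O)O)cc2)=[N+]([O-])C1(C)C`, is not yet measured. It differs from compound 2 by (1-((carboxymethyl)carbamoyl)-2-sulfanylethyl)amino in place of hydroxy on a carbonyl carbon, so the free acid of compound 2 becomes an amide that carries a further peptide-like chain. Among the measured compounds shown here, only one measured step is available for comparison, the step from compound 1 to compound 2, and it concerns a different position, the amine nitrogen, where a tert-butoxycarbonyl group was removed with no change beyond the scatter. For the measured compounds named here, no measured step touches the carbonyl carbon that is changed here, so the bearing of the data on compound 3 is indirect. Going by the values given here, the numbers so far point to the shared core giving a reading in the same range whatever is attached at these positions, and on that basis compound 3 is expected to show no step beyond the scatter, a 1.0-fold lower number from compound 2 to compound 3 (0.02 log units; within the scatter), with an estimate of 40000 nM and a range from 15000 nM to 110000 nM.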

Compound 3, half-maximal effective concentration: 37800 nM
Beside the measured number, compound 3's estimate is 1.1-fold (0.02 log units) above it; measured number inside the range.
By their numbers in this assay, from the lowest: compounds 3, 2 and 1 (each within the scatter of the next).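

Among the compounds shown here, at the carbonyl carbon whose other neighbours are a saturated chain carbon, this assay gives the first reading for any change, and the step is a 1.1-fold lower number from compound 2 to compound 3 (0.04 log units; within the scatter). The hydroxy of the free acid gives way to (1-((carboxymethyl)carbamoyl)-2-sulfanylethyl)amino, with 11 heavy atoms entering for 1 and a further defined stereocentre, yet the two numbers cannot be told apart, so the earlier finding at the amine nitrogen now has a counterpart at a second place on the side chain. Nothing measured on these compounds accounts for this reading, and no outside data bear on it.

As far as these compounds go, it remains open whether the sulfanyl group counts for anything in this chain, as a hydroxy or a methyl in its place would show, and whether a methyl ester or a simple methylamide at the same carbonyl carbon would read the same. From the compounds shown here alone, all three compounds carry the shared core, so what the number would be with that core altered, for instance with an amine in place of the ether oxygen, also stays open.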